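Aryl substituent exchange and tolerated concentration in liver cells

This account rests on a few compounds, and the source may have more. Where it says the series, first, only, none or still open, it means among the compounds named here.

Measured so far:
compound 1, `Cc1ccccc1-c1nn(-c2ccc(F)cc2)cc1CNCCN1CCN(C)CC1`: > 20000 nM
compound 2, `Cc1ccccc1-c1nn(-c2ccc(C(F)(F)F)cc2)cc1CNCCN1CCN(C)CC1`: 11000 nM

Among the compounds with values here, in an ADME assay on Huh-7 cells (Homo sapiens) for cytotoxicity (a lower number here means that less compound is tolerated, a higher number that more compound is tolerated), compound 2 gives 11000 nM, the only number obtained for the two measured compounds. For compound 1 the assay reports only a limit, > 20000 nM, which is the limit of > 20000 nM in this assay, at which 1 of the 2 values shown sits. Within the data shown here, the single measured step, an at least 1.8-fold lower number from compound 1 to compound 2 (0.25 log units; that floor lies within the scatter), therefore rests on a limit on one side and stays within the scatter at its floor.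

Compound 3 is `Cc1ccccc1-c1nn(-c2cccc(Cl)c2)cc1CNCCN1CCN(C)CC1`. Relative to compound 2 the change is 3-chlorophenyl in place of 4-(trifluoromethyl)phenyl on an aromatic nitrogen. Among the measured compounds shown here, the step from compound 1 to compound 2 is the only one bearing on this change, since it also alters the substituent on the same aryl group attached to the ring nitrogen; it moved the number down by a small amount, and reversing away from trifluoromethyl toward a single halogen may move it back, though the size of that step cannot be told beyond the scatter. A modest rise, with a real chance of reaching the limit again, is expected.

Compound 3 is estimated at 15000 nM, with a range from 7000 nM to 40000 nM. The expected step is a 1.4-fold higher number from compound 2 to compound 3 (0.13 log units; within the scatter).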

Compound 3, half-maximal cytotoxic concentration: 16000 nM
Compound 3: the middle estimate sits 1.1-fold (0.03 log units) below what was measured; the measured number falls inside the stated range.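

In this assay, the exchange on the aromatic nitrogen gives a 1.5-fold higher number from compound 2 to compound 3 (0.16 log units; within the scatter), so compound 2 and compound 3 cannot be told apart, even though the exchange alters both the substituent and where it sits on the aryl group. The second comparison gives an at least 1.2-fold lower number from compound 1 to compound 3 (0.09 log units; that floor lies within the scatter), so the 3-chlorophenyl group adds a second exchange at this position whose floor, like that of the earlier step, shows no separation beyond the scatter. The value of compound 1 is a limit of the assay and not a number: the limit of > 20000 nM in this assay, at which 1 of the 3 values shown sits.

As far as these compounds go, how far compound 1 actually lies from compound 2 and compound 3 stays open, and neither floor settles whether either step is larger than the scatter. The substituent and its location also remain tied together in the exchange to the 3-chlorophenyl group, so their separate contributions are unresolved, and the compounds shown do not tell how a 4-chlorophenyl group or an aryl group carrying an amine or a carboxylic acid would read at this nitrogen.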